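The source may hold more compounds than are shown below. What is called first, only, known or untested is meant among the compounds shown, and "the series" means these compounds.

In a functional assay on MCF7 cells (Homo sapiens) for antiproliferative activity, read by MTT assay, with a stated time of 72 h (a lower number here means a stronger inhibitor, a higher number a weaker inhibitor), compound 1 `O=C1O[C@H]([C@@H](O)Cn2cc(-c3cc(F)cc(F)c3)nn2)C(OCc2ccccc2)=C1OCc1ccccc1` gives 27700 nM, compound 2 `O=C1O[C@H]([C@@H](O)Cn2cc(CNS(=O)(=O)c3ccc(F)cc3)nn2)C(OCc2ccccc2)=C1OCc1ccccc1` gives 26800 nM, and compound 3 `COc1ccc(-c2cn(C[C@H](O)[C@H]3OC(=O)C(OCc4ccccc4)=C3OCc3ccccc3)nn2)cc1` gives 99700 nM. Compound 3 thus has the highest number of the three, set apart from the others by a 3.6-fold higher number from compound 1 to compound 3 (0.56 log units; beyond the scatter) and by a 3.7-fold higher number from compound 2 to compound 3 (0.57 log units; beyond the scatter), while the exchange of groups on the same aromatic carbon between compounds 1 and 2 gave a 1.0-fold lower number from compound 1 to compound 2 (0.01 log units; within the scatter).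

Compound 4 `O=C1O[C@H]([C@@H](O)Cn2cc(CCO)nn2)C(OCc2ccccc2)=C1OCc1ccccc1` differs from compound 3 by 2-hydroxyethyl in place of 4-methoxyphenyl on an aromatic carbon. Going by the values given here, the only measured steps at this position show that swapping one large group for another moved the number modestly or not at all; none of them replaces the large group with a short chain, so the bearing of those steps is indirect. Since compound 3 sits at the weak end and compound 1 and compound 2 show that other groups at this position give lower numbers, a modest move back toward those values is expected rather than a further rise, though a change within the scatter is also plausible. Compound 4 is therefore expected to give 40000 nM, with a range of 12000 nM to 130000 nM. This estimate corresponds to an expected step of a 2.5-fold lower number from compound 3 to compound 4 (0.40 log units; beyond the scatter).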

Compound 4, half-maximal inhibitory concentration: 63400 nM
Compound 4: middle estimate off by 1.6-fold (0.20 log units), on the low side, and the stated range covers the measured number.
By their numbers in this assay, from the lowest: compounds 2 and 1 (each within the scatter of the next); then compounds 4 and 3 (each within the scatter of the next).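

Exchanging 4-methoxyphenyl, which carries a six-membered aromatic ring, for 2-hydroxyethyl, which has no ring, gives a 1.6-fold lower number from compound 3 to compound 4 (0.20 log units; within the scatter) in this assay, so at this carbon of the five-membered aromatic ring, a short chain reads the same as this large aryl group. The short chain does not match the other two groups, however: 2-hydroxyethyl in place of 3,5-difluorophenyl gives a 2.3-fold higher number from compound 1 to compound 4 (0.36 log units; beyond the scatter), and hydroxymethyl in place of ((4-fluorophenyl)sulfonyl)amino on the saturated chain carbon gives a 2.4-fold higher number from compound 2 to compound 4 (0.37 log units; beyond the scatter). An aromatic ring on this carbon therefore does not set the number by itself, since compound 1 and compound 3 both carry one, yet only compound 1 stands apart from compound 4 beyond the scatter.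

The compounds shown leave open whether the hydroxyl group or the length of the chain matters, which a plain ethyl group, a 2-aminoethyl group or a longer chain ending in a hydroxyl group at this carbon would help to separate. No measurement is available here to explain any of these differences.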